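Three Inactive Amides and a Methylphenyl Replacement

The compounds below may be only part of what the source reports. "The series", "measured", "known", "first", "only" and "open" are said of these compounds alone.

Compound 3 `O=C(/C=C/c1ccc(Cl)cc1)Nc1cc(Sc2ncn[nH]2)c(O)c2ccccc12` carries a 2-(4-chlorophenyl)ethenyl group on the carbonyl carbon of the shared core. In a functional assay on MDA-MB-231 cells (Homo sapiens) for antiproliferative activity, read by MTT assay, with a stated time of 48 h (a lower number here means a stronger inhibitor, a higher number a weaker inhibitor), compound 3 reaches only the assay limit > 100000 nM. Compound 1 `O=C(Nc1cc(Sc2ncn[nH]2)c(O)c2ccccc12)c1cccc(Cl)c1` gives the limit > 100000 nM in this assay. Compound 2 `COc1cccc(C(=O)Nc2cc(Sc3ncn[nH]3)c(O)c3ccccc23)c1` likewise gives the limit > 100000 nM. All three share (the limit of > 100000 nM in this assay, at which 3 of the 3 values shown sit), so the steps a step that the two limits leave unreadable from compound 1 to compound 2, a step that the two limits leave unreadable from compound 1 to compound 3 and a step that the two limits leave unreadable from compound 2 to compound 3 cannot be read. Compound 4 `Cc1cccc(C(=O)Nc2cc(Sc3ncn[nH]3)c(O)c3ccccc23)c1` differs from compound 3 by 3-methylphenyl in place of 2-(4-chlorophenyl)ethenyl on a carbonyl carbon. Among the measured compounds shown here, no measured step bears on this change with a readable size, and because every measured value sits at the limit of > 100000 nM in this assay, at which 3 of the 3 values shown sit, no shift beyond the scatter in this assay is expected. Compound 4 is therefore expected at 150000 nM, between 40000 nM and 600000 nM. The step that the limit leaves unreadable from compound 3 to compound 4 is expected to be nil.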

Compound 4, half-maximal inhibitory concentration: > 100000 nM
Compound 4 ended at the assay's limit (the forecaster's own chance of this, stated with the estimate: 85%); the middle value is on the limit's open side.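

The steps from compound 1, compound 2 and compound 3 to compound 4 cannot be read, because all four compounds share one limit: the limit of > 100000 nM in this assay, at which 4 of the 4 values shown sit. The compounds shown leave open which group on the carbonyl carbon, if any, would give a readable value in this assay.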